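A few compounds are considered here, and "the series" means these few. Any claim that something is new, unique, unknown or untested is made for them only; others in the source may bear on it.

In a functional assay on cells (leukaemia cell line, Homo sapiens) for inhibition, read by sulforhodamine B assay, with a stated time of 48 h (a lower number here means a stronger inhibitor of growth, a higher number a weaker inhibitor of growth), compound 1 `O=S(=O)(Nc1cccc(Cl)c1)c1ccc(-c2cnc(C3CC3)o2)cc1` gives 54200 nM, compound 2 `O=S(=O)(Nc1ccc(F)cc1F)c1ccc(-c2cnc(C3CC3)o2)cc1` gives 66100 nM and compound 3 `O=S(=O)(Nc1cc(F)cc(Cl)c1)c1ccc(-c2cnc(C3CC3)o2)cc1` gives 77500 nM. Compound 3 cannot be ranked against the other two: the steps to it, a 1.4-fold higher number from compound 1 to compound 3 (0.16 log units; within the scatter) and a 1.2-fold higher number from compound 2 to compound 3 (0.07 log units; within the scatter), both lie within the scatter. Compound 4 `Cc1cc(Cl)ccc1NS(=O)(=O)c1ccc(-c2cnc(C3CC3)o2)cc1` has 4-chloro-2-methylphenyl in place of 3-chloro-5-fluorophenyl on a sulfonamide nitrogen. The closest evidence comes from the earlier exchanges of the group at that nitrogen, a 1.2-fold higher number from compound 1 to compound 2 (0.09 log units; within the scatter) and a 1.2-fold higher number from compound 2 to compound 3 (0.07 log units; within the scatter), and neither goes beyond the scatter. The estimated step is a 1.2-fold lower number from compound 3 to compound 4 (0.08 log units; within the scatter), so no change beyond the scatter is expected in this assay. For compound 4 the expected value is 65000 nM, with an estimated range of 35000 nM to 115000 nM.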

Compound 4, concentration for total growth inhibition: 54700 nM
Beside the measured number, compound 4's estimate is 1.2-fold (0.07 log units) above it; measured number inside the range.
By their numbers in this assay, from the lowest: compounds 1, 4, 2 and 3 (each within the scatter of the next).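

At the sulfonamide nitrogen, 4-chloro-2-methylphenyl is the first group shown that carries a methyl, and in this assay it stays within the scatter of all three earlier compounds (a 1.4-fold lower number from compound 3 to compound 4 (0.15 log units; within the scatter); a 1.2-fold lower number from compound 2 to compound 4 (0.08 log units; within the scatter); a 1.0-fold higher number from compound 1 to compound 4 (0.00 log units; within the scatter)). This position has now held four differently substituted phenyl groups with no step beyond the scatter, so the four compounds cannot be ranked. Nothing available explains this result. Still open, as far as these compounds go, is whether an amine or a carboxylic acid on the phenyl ring, or a longer chain in its place, would give a step beyond the scatter.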